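Ethoxycarbonyl on the methoxy group of compound 2

A few compounds are considered here, and "the series" means these few. Any claim that something is new, unique, unknown or untested is made for them only; others in the source may bear on it.

Measured in an ADME assay on DU-145 cells (Homo sapiens) for cytotoxicity, read by MTT assay, with a stated time of 72 h; a lower number here means a stronger inhibitor, a higher number a weaker inhibitor
compound 1 `COc1cc(C2=C(c3ccc(OCC(=O)O)cc3)C(O)CC2=O)cc(OC)c1OC` gives > 100 ug/mL (a limit)
compound 2 `COc1ccc(C2=C(c3cc(OC)c(OC)c(OC)c3)C(=O)CC2O)cc1` gives 18.7 ug/mL

Going by the values given here, compound 2 holds the only actual number so far in this assay, namely 18.7 ug/mL. The entry for compound 1 is a limit, > 100 ug/mL, and not a number.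

Compound 3 `CCOC(=O)COc1ccc(C2=C(c3cc(OC)c(OC)c(OC)c3)C(=O)CC2O)cc1` is reached from compound 2 by one change, (ethoxycarbonyl in place of hydrogen on a saturated chain carbon bound to an oxygen on an aromatic ring), which is ethoxycarbonyl in place of hydrogen on a saturated chain carbon bound to an oxygen on an aromatic ring. The same difference reads methoxy to (ethoxycarbonyl)methoxy.

Among the compounds with values here, one measured step bears on this place: an at least 5.3-fold lower number from compound 1 to compound 2 (0.72 log units; beyond the scatter). It lies beyond the scatter, and its size is only a bound. Read backwards, that step from compound 1 suggests a higher number once a group returns to this carbon. However, compound 3 carries ethoxycarbonyl and not carboxy, so only part of that step is expected to carry over. A modest rise in this assay is therefore expected, and the expected step is a 2.1-fold higher number from compound 2 to compound 3 (0.33 log units; beyond the scatter). For compound 3 the estimate is 40 ug/mL, with an expected range of 15 ug/mL to 100 ug/mL.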

Compound 3, half-maximal inhibitory concentration: > 100 ug/mL
Compound 3 was reported as a limit (the forecaster's own chance of this, stated with the estimate: 20%); at least 2.5-fold (0.39 log units) between middle value and limit.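

In this assay, ethoxycarbonyl in place of hydrogen on the saturated chain carbon bound to an oxygen on an aromatic ring gives an at least 5.3-fold higher number from compound 2 to compound 3 (0.72 log units; beyond the scatter). The entry for compound 3, > 100 ug/mL, is a limit and not a number. Going by these compounds alone, until now, the only step at this place involved carboxy, so the loss of a measurable number could have been tied to that group; with compound 3, ethoxycarbonyl also gives a limit, and the rise is not confined to the free carboxy group.

The step between compound 1 and compound 3 cannot be read, so carboxy and ethoxycarbonyl stay unranked, and the size of both steps from compound 2 remains only a bound: the limit of > 100 ug/mL in this assay, at which 2 of the 3 values shown sit. Open, going by these compounds, is whether an amine, an amide or a longer chain on this carbon would return a true number close to that of compound 2, 18.7 ug/mL. Each of these groups might instead also end at the limit.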